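The source may report more compounds than this note shows. Statements on the series, on what has been measured and on what is new or still open speak of the compounds shown alone.

Measured in a functional assay on JAR cells (Homo sapiens) for inhibition, read by MTT assay, with a stated time of 72 h, tested at 10 uM; a higher number here means more inhibition at the concentration tested (going by the name of the read-out), a lower number less inhibition:
compound 1 `CCOC(=O)C1=C(Nc2ccccc2)S/C(=C\c2ccccc2)C1=O` gives 20.3%
compound 2 `CCOC(=O)C1=C(Nc2ccccc2Br)S/C(=C\c2ccc[nH]2)C1=O` gives 62.7%
compound 3 `CCOC(=O)C1=C(Nc2cccc(F)c2)S/C(=C\c2ccc[nH]2)C1=O` gives 45.4%

Compound 1 stands lowest of the three. Compound 3 sits nearest, with 45.4% beyond the scatter above compound 1, and compound 2 is furthest at 62.7%. Compound 4 `CCOC(=O)C1=C(Nc2ccccc2)S/C(=C\c2cc[nH]c2)C1=O` differs from compound 1 in one place: 1H-pyrrol-3-yl in place of phenyl on a double-bonded chain carbon bound to a double-bonded ring carbon. Among the compounds with values here, the single measured step, a number 17.3 percentage points lower from compound 2 to compound 3 (beyond the scatter), concerns the aryl on the amine nitrogen and does not bear on this change. Within the data shown here, compounds 2 and 3 carry a pyrrolyl group in the same place and both lie above compound 1, but each differs from compound 1 in two places, so no direct step exists. Compound 4 is therefore expected to rise by a number 19.7 percentage points higher from compound 1 to compound 4 (beyond the scatter), with wide uncertainty, to an estimated 40% within 15% to 65%.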

Compound 4, a percentage reported as inhibition, at one concentration (the size of the read-out at that concentration, not a potency): 19.5%
The estimate for compound 4 lay 20.5 percentage points above the measured number; measured number inside the range.
By their numbers in this assay, from the lowest: compounds 4 and 1 (each within the scatter of the next); then compound 3; then compound 2.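

In this assay, within the data shown here, the step of a number 0.8 percentage points lower from compound 1 to compound 4 (within the scatter) gives the first direct reading of this change: with an unsubstituted phenyl on the amine nitrogen, 1H-pyrrol-3-yl and phenyl on the double-bonded chain carbon cannot be told apart. A pyrrolyl group in this place is therefore not enough by itself to separate a compound from compound 1. No measurement shown explains this result. Still open, on these data alone, is whether a furan ring or a phenyl carrying a dimethylamino group in this place would separate from compound 1.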